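This account rests on a few compounds, and the source may have more. Where it says the series, first, only, none or still open, it means among the compounds named here.

Measured so far in a functional assay on NCI-H1975 cells (Homo sapiens) for inhibition, read by MTT assay, with a stated time of 72 h; on this read-out lower numbers stand for stronger inhibition and higher numbers for weaker inhibition:
- compound 1 `O=C(CSc1nc(Nc2ccccc2)c2ccccc2n1)Nc1ccccc1Cl`: 9610 nM
- compound 2 `O=C(CSc1nc(Nc2ccccc2)c2ccccc2n1)Nc1cccc(Cl)c1`: 8460 nM
- compound 3 `O=C(CSc1nc(Nc2ccccc2)c2ccccc2n1)Nc1cccc(Br)c1`: 10100 nM

All three compounds share one core and differ only in the ring carried on the amide nitrogen. Compound 3 has the highest number of the three, but its gap to compound 1 and to compound 2 is within the scatter, so on this assay the three are indistinguishable. The steps confirm this: a 1.1-fold lower number from compound 1 to compound 2 (0.06 log units; within the scatter), a 1.1-fold higher number from compound 1 to compound 3 (0.02 log units; within the scatter) and a 1.2-fold higher number from compound 2 to compound 3 (0.08 log units; within the scatter) are all within the scatter, so neither moving the halogen around the ring nor exchanging chloro for bromo shifts the read-out.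

Compound 4 `C=CC(=O)Nc1cccc(NC(=O)CSc2nc(Nc3ccccc3)c3ccccc3n2)c1` is built from compound 3 by (vinylcarbonyl)amino in place of bromo on an aromatic carbon. This is a different kind of change from the halogen exchanges above: a halogen leaves and a group with an amide-type donor, an acceptor and two double bonds enters. Among the measured compounds shown here, none of the measured steps involves such a group, so they set no size for this step; they only show that the ring position itself tolerates variation. The estimate therefore rests mainly on the shared core, with a wide range: compound 4 is expected to give 4000 nM in this assay, between 700 nM and 20000 nM, which means an expected step of a 2.5-fold lower number from compound 3 to compound 4 (0.40 log units; beyond the scatter).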

Compound 4, half-maximal inhibitory concentration: 8120 nM
Compound 4: the middle estimate sits 2.0-fold (0.31 log units) below what was measured; low and high end bracket the measured number.
By their numbers in this assay, from the lowest: compounds 4, 2, 1 and 3 (each within the scatter of the next).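

In this assay, the halogen on the ring gives way to (vinylcarbonyl)amino, and the steps of a 1.2-fold lower number from compound 3 to compound 4 (0.09 log units; within the scatter) and a 1.0-fold lower number from compound 2 to compound 4 (0.02 log units; within the scatter) and also a 1.2-fold lower number from compound 1 to compound 4 (0.07 log units; within the scatter) all leave compound 4 indistinguishable from the halogen compounds. The earlier compounds shown here showed only that one halogen could replace another or sit elsewhere on this ring; this result shows that the place also accepts a group of 5 heavy atoms in place of a single one, carrying a hydrogen-bond donor, a hydrogen-bond acceptor and 2 double bonds outside aromatic rings, with no step beyond the scatter. Nothing available here bears on why the read-out responds so little to this exchange.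

Going by these compounds, whether an amine or a carboxylic acid at this place would move the number beyond the scatter remains open, as does whether propanoylamino, the same group with its carbon-carbon double bond saturated, would read alike. All four compounds also share one core, so the effect of adding a methoxy group elsewhere on that core is equally unknown.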